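This account rests on a few compounds, and the source may have more. Where it says the series, first, only, none or still open, it means among the compounds named here.

In a functional assay on cells (T-cell, Homo sapiens) for inhibition, read by scintillation counting and thymidine incorporation, with stated times of 60 min and 3 days (a lower number here means a stronger inhibitor, a higher number a weaker inhibitor), the measured compounds are as follows:

- compound 1 `COc1ccc(-c2cc3c(NC(CO)[C@H](O)C4CC4)c(C(N)=O)cnn3c2)cn1` gives 4800 nM; 500 nM (2 entries)
- compound 2 `COc1ccc(-c2cc3c(NC(CO)CO)c(C(N)=O)cnn3c2)cn1` gives 11000 nM
- compound 3 `C[C@H](O)[C@H](CO)Nc1c(C(N)=O)cnn2cc(-c3ccccc3)cc12` gives 2000 nM

Compound 3 (2000 nM) holds the lowest single number in this small set. It stands below compound 2 (11000 nM), and that gap lies beyond the scatter. From the compounds shown here alone, compound 1 has two entries that do not reduce to one number, so its place relative to compound 3 remains open.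

Compound 4 `C[C@@H](O)[C@H](CO)Nc1c(C(N)=O)cnn2cc(-c3ccccc3)cc12` is not yet measured. Its change from compound 3 is the two compounds have the same atoms and bonds and differ only in configuration as drawn: 1 of 2 stereo elements differ; a stereocentre at a saturated chain carbon is drawn S in compound 3 and R in compound 4 and no other part of the structure is altered.

For the measured compounds named here, no measured pair in this set isolates a change of configuration, so the size of this step is a matter of judgement. A modest move toward a higher number is expected, possibly not beyond the scatter, since compound 3 (2000 nM) already holds the lowest single number. The range is kept wide because the several entries of compound 1 in this assay, 4800 nM; 500 nM (2 entries) show how far repeated entries can part in this series. The expected move is a 1.5-fold higher number from compound 3 to compound 4 (0.18 log units; within the scatter) and it remains an estimate only. Compound 4 is estimated at 3000 nM (expected range 800 nM to 11000 nM).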

Compound 4, half-maximal inhibitory concentration: 1800 nM
Compound 4: the middle estimate sits 1.7-fold (0.22 log units) above what was measured; the measured number falls inside the stated range.
By their numbers in this assay, from the lowest: compounds 4 and 3 (each within the scatter of the next); then compound 2.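

In this assay, for the compounds shown here, inverting the stereocentre at the saturated chain carbon gives a 1.1-fold lower number from compound 3 to compound 4 (0.05 log units; within the scatter), which makes this the first pair to isolate a single change, and at this position the drawn configuration leaves the number within the scatter. The comparison bears on configuration alone, since no other part of the structure changes: the fact that compounds 3 and 4 differ only in the configuration as drawn. The small step still calls for some care, because repeated entries in this series can lie far apart: the several entries of compound 1 in this assay, 4800 nM; 500 nM (2 entries)

The compounds shown leave open whether the second stereo element, drawn alike in compound 3 and compound 4, would also give a step within the scatter if it were inverted. They also leave open how the number in this assay would respond if an amine stood in place of the hydroxyl at this saturated chain carbon, and whether the same inversion would give a similar step in that setting.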